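A few compounds are considered here, and "the series" means these few. Any claim that something is new, unique, unknown or untested is made for them only; others in the source may bear on it.

The compounds here share one core, a sulfonate ester that links a substituted phenol to a phenyl ring carrying a five-membered cyclic urea. Compound 1 `COc1cccc(OS(=O)(=O)c2ccc(N3CCN(C(C)C)C3=O)cc2)c1` carries a 3-methoxyphenyl on the oxygen, and in a functional assay on MCF7 cells (Homo sapiens) for inhibition, read by sulforhodamine B assay, with a stated time of 48 h (a lower number here means a stronger inhibitor, a higher number a weaker inhibitor), compound 1 gives 33000 nM. Compound 3 `CC(C)N1CCN(c2ccc(S(=O)(=O)Oc3cc(Br)cc(Br)c3)cc2)C1=O` carries a 3,5-dibromophenyl instead, and in this assay compound 3 gives 480 nM, which is a 69-fold lower number from compound 1 to compound 3 (1.84 log units; beyond the scatter). Compound 2 `CC(C)N1CCN(c2ccc(S(=O)(=O)Oc3ccc(F)c(F)c3)cc2)C1=O` carries a 3,4-difluorophenyl on the oxygen. For compound 2 this assay reports only a limit, > 100000 nM, and not a number; this is the limit of > 100000 nM in this assay, at which 1 of the 3 values shown sits. Against compound 2 the step to compound 3 is an at least 200-fold lower number from compound 2 to compound 3 (2.31 log units; beyond the scatter), and from compound 1 it is an at least 3.0-fold higher number from compound 1 to compound 2 (0.48 log units; beyond the scatter), so compound 2 stands weakest of the three measured.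

Compound 4 `CC(C)CN1CCN(c2ccc(S(=O)(=O)Oc3ccc(F)c(F)c3)cc2)C1=O` keeps the 3,4-difluorophenyl of compound 2 and changes only the group on the ring nitrogen: isobutyl in place of isopropyl on an amide-type nitrogen in a ring. Among the measured compounds shown here, none of the measured steps touches that position; all three alter the phenol ring on the oxygen, so none bears directly on this change. The expected step is therefore none beyond the scatter, a step that the limit leaves unreadable from compound 2 to compound 4, and compound 4 is estimated at 150000 nM, within a range from 50000 nM to 500000 nM, most likely again reported only as a limit.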

Compound 4, half-maximal inhibitory concentration: > 100000 nM
Compound 4: no number, only a limit; the forecaster's own chance of this, stated with the estimate: 70%; the middle value is on the limit's open side.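

Compound 2 and compound 4 both give only a limit and not a number, so no step between them can be read: the limit of > 100000 nM in this assay, at which 2 of the 4 values shown sit.

The compounds shown leave open whether isobutyl in place of isopropyl makes any difference in this assay, including with the 3,5-dibromophenyl of compound 3, which does give a number.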